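Aryl substitution on the triazole in the oxime ether series

The source may hold more compounds than are shown below. What is called first, only, known or untested is meant among the compounds shown, and "the series" means these compounds.

For the measured compounds named here, compound 1 `CC(C)=CCC/C(C)=C/CC/C(C)=C/CC[C@@H]1[C@@]2(C)CC/C(=N\OCc3cn(-c4ccccc4)nn3)C(C)(C)[C@@H]2CC[C@@]1(C)O` gives 7760 nM in a functional assay on HeLa cells (Homo sapiens) for cytotoxicity, read by MTT assay, with a stated time of 48 h (on this read-out lower numbers stand for stronger inhibition and higher numbers for weaker inhibition), the lowest of the three numbers measured so far. Compound 2 `CC(C)=CCC/C(C)=C/CC/C(C)=C/CC[C@@H]1[C@@]2(C)CC/C(=N\OCc3cn(-c4ccc(F)cc4)nn3)C(C)(C)[C@@H]2CC[C@@]1(C)O` gives 21400 nM and compound 3 `CC(C)=CCC/C(C)=C/CC/C(C)=C/CC[C@@H]1[C@@]2(C)CC/C(=N\OCc3cn(-c4ccccc4C#N)nn3)C(C)(C)[C@@H]2CC[C@@]1(C)O` gives 21200 nM; both steps away from compound 1 lie beyond the scatter, namely a 2.8-fold higher number from compound 1 to compound 2 (0.44 log units; beyond the scatter) and a 2.7-fold higher number from compound 1 to compound 3 (0.44 log units; beyond the scatter). Between the two substituted analogues a 1.0-fold lower number from compound 2 to compound 3 (0.00 log units; within the scatter), so fluoro and cyano land in the same range. Compound 4 `CC(C)=CCC/C(C)=C/CC/C(C)=C/CC[C@@H]1[C@@]2(C)CC/C(=N\OCc3cn(-c4ccc(F)c(Cl)c4)nn3)C(C)(C)[C@@H]2CC[C@@]1(C)O` carries 3-chloro-4-fluorophenyl in place of phenyl on an aromatic nitrogen. Going by the values given here, the step that bears on it is fluoro in place of hydrogen on an aromatic carbon, which raised the number from compound 1 to compound 2 beyond the scatter; compound 4 keeps that fluorine and adds a chlorine, for which no measured step exists. A rise of the number rather than a fall is therefore expected, of roughly the size seen for compound 2. The estimate for compound 4 is 20000 nM, with a range of 8000 nM to 50000 nM, corresponding to the expected step of a 2.6-fold higher number from compound 1 to compound 4 (0.41 log units; beyond the scatter).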

Compound 4, half-maximal inhibitory concentration: 20100 nM
Compound 4: the middle estimate sits 1.0-fold (0.00 log units) below what was measured; the measured number falls inside the stated range.
By their numbers in this assay, from the lowest: compound 1; then compounds 4, 3 and 2 (each within the scatter of the next).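

On the aryl group at the aromatic nitrogen, chloro in place of hydrogen now has a measured step in this assay, a 1.1-fold lower number from compound 2 to compound 4 (0.03 log units; within the scatter), so the chlorine of compound 4 adds no readable difference to the fluorine of compound 2. The 3-chloro-4-fluorophenyl and 2-cyanophenyl groups also cannot be told apart, with a 1.1-fold lower number from compound 3 to compound 4 (0.02 log units; within the scatter), while the step from the unsubstituted phenyl group is a 2.6-fold higher number from compound 1 to compound 4 (0.41 log units; beyond the scatter); all three substituted compounds shown therefore stand above compound 1, and none goes against this. No measurement shown accounts for this pattern.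

Still open, from the compounds shown here alone, is whether any substituent at this aryl group gives a lower number than compound 1, for example an amine, a methoxy group or a carboxylic acid. Also open, going by these compounds, is how a chlorine behaves on the phenyl group without the fluorine.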